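A few compounds are considered here, and "the series" means these few. Any claim that something is new, unique, unknown or untested is made for them only; others in the source may bear on it.

In a functional assay on CCRF-CEM cells (Homo sapiens) for inhibition (on this read-out higher numbers stand for weaker inhibition and lower numbers for stronger inhibition), three compounds have been measured so far. Compound 1, `Nc1nc(N)c2nc(CNc3ccc(C(=O)NC(CNC(=O)c4ccccc4C(=O)O)C(=O)O)cc3)cnc2n1`, gives 5.1 nM. Compound 2, `Nc1nc(N)c2nc(CNc3ccc(C(=O)NC(CCCNC(=O)c4ccc(C(=O)O)cc4)C(=O)O)cc3)cnc2n1`, gives 55 nM. Compound 3, `Nc1nc(N)c2nc(CCc3ccc(C(=O)NC(CCCNC(=O)c4ccccc4C(=O)O)C(=O)O)cc3)cnc2n1`, gives 0.53 nM. Compound 3 thus stands at the lowest number of the three and is the most potent of them: its distance to compound 1 and its still larger distance to compound 2 both lie beyond the usual scatter of this assay.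

Compound 4, `CC(Cc1cnc2nc(N)nc(N)c2n1)c1ccc(C(=O)NC(CCCNC(=O)c2ccccc2C(=O)O)C(=O)O)cc1`, has not yet been measured. It differs from compound 3 in a single place: methyl in place of hydrogen on a saturated chain carbon bound to an aromatic carbon and a saturated chain carbon, that is, on the chain that joins the shared core to the remainder of the molecule. Among the compounds with values here, no pair among the measured compounds differs in the same way, so the measured set itself shows nothing about what such a methyl does in this assay. The estimate can rest only on the standing of compound 3 at 0.53 nM and on the small size of the added group.

The step from compound 3 to compound 4 is expected to be a 1.5-fold higher number from compound 3 to compound 4 (0.18 log units; within the scatter), a small move toward a higher number that is not expected to exceed the scatter. Compound 4 is therefore expected to give 0.8 nM in this assay, within a range from 0.2 nM to 3.2 nM.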

Compound 4, half-maximal inhibitory concentration: 0.63 nM
Estimate against measurement, compound 4: 1.3-fold (0.10 log units) above; the range from low to high includes it.
By their numbers in this assay, from the lowest: compounds 3 and 4 (each within the scatter of the next); then compound 1; then compound 2.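

In this assay, within the data shown here, methyl in place of hydrogen on a saturated chain carbon bound to an aromatic carbon and a saturated chain carbon gives a 1.2-fold higher number from compound 3 to compound 4 (0.08 log units; within the scatter), the first step that can be read for a single change. It shows that on the chain joining the shared core to the remainder of the molecule, this carbon can carry one more heavy atom while the numbers of the two compounds remain indistinguishable within the usual scatter of this read-out. Nothing in the data shown bears on what lies behind this result.

The compounds shown leave open whether ethyl, a hydroxyl group or an amine on the same saturated chain carbon, or a second methyl there, would also give a number indistinguishable from that of compound 3. Among these compounds, they also leave open whether the same methyl would behave in this way on the differently built chains of compound 1 and compound 2, where the group joining the shared core to the remainder of the molecule is not the one found in compound 3.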